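Swapping Acetyl for Ethyl on the Ring Nitrogen

A few compounds are considered here, and "the series" means these few. Any claim that something is new, unique, unknown or untested is made for them only; others in the source may bear on it.

Of the compounds shown here, three have been measured in an assay on HEK293 cells for inhibition of acid ceramidase (Homo sapiens), read by fluorescence, with stated times of 10 min and 3 h; a higher number here means a weaker inhibitor, a lower number a stronger inhibitor. Compound 2 `CC(=O)N1CCC(c2ccc3c(c2)oc(=O)n3C(=O)NCCCCc2ccccc2)CC1` gives 64 nM, the lowest of the three numbers. Compound 1 `CC(C)CNC(=O)n1c(=O)oc2ccc(C3CCN(C)CC3)cc21` gives 295 nM in this assay, a gap beyond the usual scatter, and compound 3 `CCOCCNC(=O)n1c(=O)oc2cc(C3CCN(C)CC3)ccc21` gives 1050 nM, the furthest away. No two of these compounds differ in only one place, so no single-point step can be read from them.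

Compound 4 `CCN1CCC(c2ccc3c(c2)oc(=O)n3C(=O)NCCCCc2ccccc2)CC1` has not yet been measured. It differs from compound 2 by ethyl in place of acetyl on an amine nitrogen in a ring; cut one bond further out, the change reads 1-acetylpiperidin-4-yl to 1-ethylpiperidin-4-yl. Going by the values given here, no measured pair shows this change. Compounds 1 and 3 carry an alkyl group on that nitrogen and sit higher than compound 2, but they differ elsewhere too, so they give only a loose hint. A modest rise in the number is expected, a step of a 2.3-fold higher number from compound 2 to compound 4 (0.37 log units; beyond the scatter). Compound 4 is estimated at 150 nM, with a range from 40 nM to 600 nM.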

Compound 4, half-maximal inhibitory concentration: 92 nM
The estimate for compound 4 lay 1.6-fold (0.21 log units) above the measured number, and the stated range covers the measured number.
By their numbers in this assay, from the lowest: compounds 2 and 4 (each within the scatter of the next); then compound 1; then compound 3.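

In this assay, going by these compounds alone, this is the first step that isolates the group on the ring nitrogen: a 1.4-fold higher number from compound 2 to compound 4 (0.16 log units; within the scatter), for ethyl in place of acetyl. With the rest of the molecule held constant, the position accepts either group with no difference beyond the usual scatter, even though the hydrogen-bond acceptor of the acetyl leaves with it. Nothing available gives a measured account of why the two compounds read alike.

As far as these compounds go, how this nitrogen responds to other groups, such as a benzyl group, a sulfonyl group or a longer chain bearing a carboxylic acid, remains open. It is also unknown whether the same swap would read alike with a different chain on the urea nitrogen, such as the shorter chains of compound 1 and compound 3.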